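Methoxyphenyl for bromophenyl on the shared core

A few compounds are considered here, and "the series" means these few. Any claim that something is new, unique, unknown or untested is made for them only; others in the source may bear on it.

Compound 2 `Brc1ccc(-c2cn3ccnc3c(-c3ccc4ncn(C5CCCCC5)c4c3)n2)cc1` gives 16.2% in a functional assay on EKVX cells (Homo sapiens) for inhibition, read by sulforhodamine B assay, with a stated time of 48 h, tested at 10 uM; on this read-out higher numbers stand for more inhibition at the one concentration tested (going by the name of the read-out) and lower numbers for less inhibition. Among the measured compounds shown here, its only neighbour is compound 1 `Brc1cn2ccnc2c(-c2ccc3ncn(C4CCCCC4)c3c2)n1`, which gives 12%; the step of a number 4.2 percentage points higher from compound 1 to compound 2 (within the scatter) leaves the two within the scatter, so neither stands apart. Compound 3 `COc1ccccc1-c1cn2ccnc2c(-c2ccc3ncn(C4CCCCC4)c3c2)n1` carries 2-methoxyphenyl in place of 4-bromophenyl on an aromatic carbon. For the measured compounds named here, no measured step swaps one aryl group for another; the only step seen, from bromo to 4-bromophenyl, was within the scatter, so nothing argues for a step beyond the scatter here either. Compound 3 is therefore expected to show a number 1.2 percentage points lower from compound 2 to compound 3 (within the scatter), with an estimated 15% and a range from 4% to 28%.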

Compound 3, a percentage reported as inhibition, at one concentration (the size of the read-out at that concentration, not a potency): 13.4%
Compound 3: the middle estimate sits 1.6 percentage points above what was measured; the measured number falls inside the stated range.
By their numbers in this assay, from the lowest: compounds 1, 3 and 2 (each within the scatter of the next).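

Swapping one aryl group for another at this position, with a hydrogen-bond acceptor entering, gives a number 2.8 percentage points lower from compound 2 to compound 3 (within the scatter) in this assay, so this aryl change does not separate the two compounds. Against the bromo compound, 2-methoxyphenyl gives a number 1.4 percentage points higher from compound 1 to compound 3 (within the scatter) and, like 4-bromophenyl, stands within the scatter of bromo. No measurement on hand explains these numbers.

The compounds shown leave open whether an amine or a carboxylic acid on this aryl ring would give a number beyond the scatter. Group and ring placement change together from compound 2 to compound 3, so their contributions cannot be told apart.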